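Three Inactive Amides and a Longer Dialkylamino Group

This account rests on a few compounds, and the source may have more. Where it says the series, first, only, none or still open, it means among the compounds named here.

Measured compounds:
compound 1, `O=C(c1cc(Cc2n[nH]c(=O)c3ccccc23)ccc1F)N1CCc2nc(N3CCCCC3)ncc2C1`: > 200000 nM
compound 2, `CN(C)CCN(C)c1ncc2c(n1)CCN(C(=O)c1cc(Cc3n[nH]c(=O)c4ccccc34)ccc1F)C2`: > 200000 nM
compound 3, `CCN(CC)c1ncc2c(n1)CCN(C(=O)c1cc(Cc3n[nH]c(=O)c4ccccc34)ccc1F)C2`: > 200000 nM

All three share one core and differ only in the amino group that sits on an aromatic carbon of that core. In a functional assay on MDA-MB-231 cells (Homo sapiens) for inhibition, read by MTT assay, with a stated time of 48 h (a higher number here means a weaker inhibitor, a lower number a stronger inhibitor), compound 1 gives > 200000 nM, which is a limit of the assay and not a number. Compound 2 gives > 200000 nM, again a limit. Compound 3 gives > 200000 nM, also a limit. The steps a step that the two limits leave unreadable from compound 1 to compound 2, a step that the two limits leave unreadable from compound 1 to compound 3 and a step that the two limits leave unreadable from compound 2 to compound 3 therefore have no readable size; all that is known is the limit of > 200000 nM in this assay, at which 3 of the 3 values shown sit.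

Compound 4, `CCCN(CCC)c1ncc2c(n1)CCN(C(=O)c1cc(Cc3n[nH]c(=O)c4ccccc34)ccc1F)C2`, is not yet measured. It differs from compound 3 by dipropylamino in place of diethylamino on an aromatic carbon. Among the measured compounds shown here, no measured step bears on exchanging diethylamino for dipropylamino, and the three measured steps themselves carry no readable size, so nothing points toward a gain in potency. The most likely outcome is that compound 4 also sits at the limit, and the expected step of a number no higher from compound 3 to compound 4 (the limit leaves the size open) is none beyond the scatter. Compound 4 is therefore estimated at 200000 nM, with a range from 50000 nM to 500000 nM, most probably reported only as a limit.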

Compound 4, half-maximal inhibitory concentration: > 200000 nM
Compound 4 was reported as a limit; the forecaster's own chance of this, stated with the estimate: 85%; the middle value sits exactly at the limit.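

In this assay compound 4 gives > 200000 nM, a limit of the assay and not a number. No step from compound 1, compound 2 or compound 3 to compound 4 can be read, so the size of each stays unknown: the limit of > 200000 nM in this assay, at which 4 of the 4 values shown sit.

The compounds shown leave open whether any amino group on this shared core gives a readable value in this assay.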